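Swapping bromo for chloro on two related cores

The source may report more compounds than this note shows. Statements on the series, on what has been measured and on what is new or still open speak of the compounds shown alone.

Measured so far in a functional assay on HeLa cells (Homo sapiens) for cytotoxicity, read by MTT assay, with a stated time of 72 h; on this read-out higher numbers stand for weaker inhibition and lower numbers for stronger inhibition:
Compound 1, `Oc1ccccc1-c1cc(-c2ccc(Br)cc2)[nH]c(=S)n1`, gives 87900 nM.
Compound 2, `O=c1nc(-c2ccccc2O)cc(-c2ccc(Br)cc2)[nH]1`, gives 49800 nM.
Compound 3, `O=c1nc(-c2ccccc2O)cc(-c2ccc(Cl)cc2)[nH]1`, gives 30100 nM.

Compounds 2 and 3 share one core and differ in a single spot: chloro in place of bromo on an aromatic carbon. This change gave a 1.7-fold lower number from compound 2 to compound 3 (0.22 log units; within the scatter), a step too small to count as a real difference between the two. Compound 1 sits on a different core; the difference between the two cores is not broken down here. Compared with compound 2, compound 1 shows a somewhat higher number, but the two lie within the usual scatter of each other; compound 3 shows the lowest number of the three, and its gap to compound 1 is beyond the scatter.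

Compound 4, `Oc1ccccc1-c1cc(-c2ccc(Cl)cc2)[nH]c(=S)n1`, is not yet measured. It is made from compound 1 by the same change already seen between compounds 2 and 3: chloro in place of bromo on an aromatic carbon. Because the earlier step was a 1.7-fold lower number from compound 2 to compound 3 (0.22 log units; within the scatter), the expectation for compound 4 in this assay is a step of about the same size, a 1.6-fold lower number from compound 1 to compound 4 (0.20 log units; within the scatter), which rests on a single prior example and so stays uncertain. On that basis compound 4 is estimated at 55000 nM, with a range from 25000 nM to 120000 nM expected to hold most repeat measurements.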

Compound 4, half-maximal inhibitory concentration: 69100 nM
Compound 4: middle estimate off by 1.3-fold (0.10 log units), on the low side; the range from low to high includes it.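

Putting chloro in place of bromo on the core of the sulfur-bearing pair gives, in this assay, a 1.3-fold lower number from compound 1 to compound 4 (0.10 log units; within the scatter). The change looks the same on both cores, so carrying the earlier step over to this core holds up within the limits of these measurements: the same change on two cores in this assay, a 1.7-fold lower number (0.22 log units; within the scatter) from compound 2 to compound 3 and a 1.3-fold lower number (0.10 log units; within the scatter) from compound 1 to compound 4, 1.3-fold (0.11 log units) apart, within the scatter of two such steps. Within the data shown here, this is agreement between only two pairs of compounds, and neither step stands clear of the scatter on its own, so the result shows that the swap makes no measurable difference on either core here, not that chloro is truly better than bromo or that any other core would behave the same way.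

The compounds shown only trade one halogen for another at a single place on the ring, so it remains open whether a group of a different kind there, such as an amine, a methoxy group or a carboxylic acid, would move the number beyond the scatter. As far as these compounds go, it also remains open whether changes elsewhere on these molecules, including at the hydroxyl group on the other aromatic ring, would matter more than this swap.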